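The source may hold more compounds than are shown below. What is called first, only, known or untested is meant among the compounds shown, and "the series" means these compounds.

Of the compounds shown here, two have been measured in an in vitro assay on SH-SY5Y cells for displacement of a labelled ligand from Neuronal acetylcholine receptor; alpha3/beta4 (Homo sapiens) (on this read-out lower numbers stand for stronger inhibition and higher numbers for weaker inhibition), so far. Compound 1, with the structure `CN1CC2C=C(c3cncc(C#N)c3)CC(C2)C1`, gives 4500 nM. Compound 2, with the structure `Clc1ccc(Oc2cncc(C3=CC4CNCC(C3)C4)c2)cc1`, gives 40 nM. For the measured compounds named here, of these two numbers, the one for compound 2 is the lower, and the gap to compound 1 is far beyond the usual scatter, so compound 2 binds the receptor more tightly than compound 1.

The next compound, compound 3, has the structure `COc1ccc(Oc2cncc(C3=CC4CNCC(C3)C4)c2)cc1`. It differs from compound 2 in one place: methoxy in place of chloro on an aromatic carbon. Seen one bond further out, the change reads 4-chlorophenyl to 4-methoxyphenyl, sitting para to a large group.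

Going by the values given here, no pair of measured compounds differing in only one place exists here, so nothing measured tells how such a swap shifts the number. The expectation is therefore a small step, a 1.5-fold higher number from compound 2 to compound 3 (0.18 log units; within the scatter), not clearly beyond the scatter in either direction. Compound 3 is expected to give about 60 nM in this assay, within a range from 20 nM to 200 nM.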

Compound 3, inhibition constant: 27 nM
Compound 3: the middle estimate sits 2.2-fold (0.35 log units) above what was measured; low and high end bracket the measured number.
By their numbers in this assay, from the lowest: compounds 3 and 2 (each within the scatter of the next); then compound 1.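

In this assay, for the compounds shown here, the swap of methoxy in place of chloro, on an aromatic carbon para to a large group, gives a 1.5-fold lower number from compound 2 to compound 3 (0.17 log units; within the scatter) and this is the first direct reading of any change at this position. The two groups differ in what is counted: chloro brings one heavy atom and no hydrogen-bond acceptor, while methoxy brings two heavy atoms and one hydrogen-bond acceptor, yet the two numbers stay within the scatter of each other, so this assay does not tell these two groups apart here. Nothing available explains why the two groups read alike.

The compounds shown hold just these two groups at this position, so it stays open whether an amine, a carboxylic acid or a longer chain such as butoxy would also stay within the scatter or would shift the number clearly. As far as these compounds go, it also stays open how the same swap would read elsewhere on this ring or on a different core, since one pair gives a single reading in a single setting.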